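Swapping a Methyl for Hydrogen on an Aromatic Nitrogen

The source may report more compounds than this note shows. Statements on the series, on what has been measured and on what is new or still open speak of the compounds shown alone.

In a functional assay on Caco-2 cells (Homo sapiens) for cytotoxicity, read by MTT assay, with stated times of 6 h and 48 h (on this read-out lower numbers stand for stronger inhibition and higher numbers for weaker inhibition), compound 1 `Cn1c(/C=C/C(=O)c2ccccc2O)cc(Br)c1Br` gives 3160 nM. Compound 3 `Cn1c(/C=C/C(=O)c2ccc(O)cc2O)cc(Br)c1Br` gives 3530 nM, and a 1.1-fold higher number from compound 1 to compound 3 (0.05 log units; within the scatter) leaves the two level. Compound 2 `Cn1c(/C=C/C(=O)c2ccccc2)cc(Br)c1Br` is reported only as a limit, >= 100000 nM. Compound 1 therefore stands level with compound 3, and it is one of the two compounds here with a measured number rather than a limit.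

Compound 4 `O=C(/C=C/c1cc(Br)c(Br)[nH]1)c1ccccc1O` keeps the core of compound 1 with a single change: hydrogen in place of methyl on an aromatic nitrogen. Neither measured step touches that nitrogen. Both concern a hydroxy on an aromatic carbon, so they offer only indirect guidance. Compound 4 keeps the hydroxy whose replacement gave an at least 31-fold higher number from compound 1 to compound 2 (1.50 log units; beyond the scatter), so an estimate should start from the value of compound 1, 3160 nM. Going by the values given here, the data hold no measured step on the nitrogen, so the direction remains open and no shift beyond the scatter is assumed. The expected step is a 1.1-fold higher number from compound 1 to compound 4 (0.04 log units; within the scatter). For compound 4 the estimated value is 3500 nM, with an expected range from 1200 nM to 12000 nM.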

Compound 4, half-maximal inhibitory concentration: >= 100000 nM
Compound 4 ended at the assay's limit; the forecaster's own chance of this, stated with the estimate: 5%; middle value at least 28-fold (1.45 log units) from the limit.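

In this assay, going by these compounds alone, replacing the methyl on the aromatic nitrogen with hydrogen gives an at least 31-fold higher number from compound 1 to compound 4 (1.50 log units; beyond the scatter), so this position, which no earlier step touched, clearly matters. The value of compound 4 is a limit, not a number, and it is the same limit reached elsewhere in this small set: the limit of >= 100000 nM in this assay, at which 2 of the 4 values shown sit. Among the compounds shown, only compound 1 and compound 3, which carry both the methyl on the nitrogen and the hydroxy that was removed in the step to compound 2, give measured numbers, whereas compound 2 and compound 4 each lack one of these two groups and sit at the limit.

With only methyl and hydrogen shown on this nitrogen, it remains open whether an ethyl group, a longer chain or a chain ending in an amine would keep the activity seen for compound 1 or lose it as compound 4 does. Going by these compounds, it also remains open whether the extra hydroxy of compound 3 would change the outcome when the nitrogen bears hydrogen.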